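Ethoxy added to the aromatic ring of compound 2

The source may report more compounds than this note shows. Statements on the series, on what has been measured and on what is new or still open speak of the compounds shown alone.

Measured so far in an assay on isolated protein for inhibition of cathepsin S (Homo sapiens), read by fluorescence; a lower number here means a stronger inhibitor, a higher number a weaker inhibitor:
Compound 1 `CC(C=O)NC(=O)c1cccc(C(F)(F)F)c1Cl` gives 110 nM.
Compound 2 `CC(NC(=O)c1cccc(C(F)(F)F)c1Cl)C(=O)C(=O)Nc1cc[nH]n1` gives 14.1 nM.
Compound 3 `CC(NC(=O)c1cccc(C(F)(F)F)c1Cl)C(=O)C(N)=O` gives 30.9 nM.

Compound 2 gives the lowest number of the three. Its nearest neighbour is compound 3, reached by a 2.2-fold higher number from compound 2 to compound 3 (0.34 log units; beyond the scatter); the largest step in the set is a 7.8-fold lower number from compound 1 to compound 2 (0.89 log units; beyond the scatter), with a 3.6-fold lower number from compound 1 to compound 3 (0.55 log units; beyond the scatter) between. All three steps turn on what is attached to the carbonyl carbon at the end of the chain; the ring bearing the trifluoromethyl and chloro groups is identical in every measured compound.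

Compound 4 `CCOc1ccc(C(=O)NC(C)C(=O)C(=O)Nc2cc[nH]n2)c(Cl)c1C(F)(F)F` differs from compound 2 only on that ring: ethoxy in place of hydrogen on an aromatic carbon. Among the compounds with values here, no measured step touches this ring, so the data give no direction for the change, and the plain expectation is a number close to that of compound 2. The value for compound 4 in this assay is therefore estimated at 14 nM, with a range of 5 nM to 40 nM. The expected step of a 1.0-fold lower number from compound 2 to compound 4 (0.00 log units; within the scatter) stays within the scatter.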

Compound 4, half-maximal inhibitory concentration: 2.9 nM
For compound 4 the middle estimate is 4.8-fold (0.68 log units) above the measured one, outside the stated range (below it).
By their numbers in this assay, from the lowest: compound 4; then compound 2; then compound 3; then compound 1.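

In this assay, the ring carbon ortho to the trifluoromethyl group and para to a large group accepts ethoxy in place of hydrogen, and the number falls: a 4.9-fold lower number from compound 2 to compound 4 (0.69 log units; beyond the scatter). Within the data shown here, the ring was constant across compound 1, compound 2 and compound 3, so this is the first sign that it also moves the number, and not only the group on the carbonyl carbon at the end of the chain. No available evidence bears on the reason for the drop.

Only ethoxy is shown at this carbon, so it remains open whether methoxy, a longer chain such as butoxy, or an amine would move the number the same way. Also open, as far as these compounds go, is whether ethoxy gives a similar step on compound 3, with its carbamoyl end.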